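From furan-3-yl to thiophen-3-yl: working notes

The compounds below may be only part of what the source reports. "The series", "measured", "known", "first", "only" and "open" are said of these compounds alone.

Measured in an ADME assay on BJ cells (Homo sapiens), read by MTT assay, with a stated time of 72 h; a lower number here means a stronger inhibitor, a higher number a weaker inhibitor:
compound 1 `Cc1ncnc2c1c(-c1ccsc1)cn2[C@@H]1O[C@H](CO)[C@@H](O)[C@H]1O`: 96900 nM
compound 2 `Nc1nc2c(c(-c3ccco3)cn2[C@@H]2O[C@H](CO)[C@@H](O)[C@H]2O)c(=O)[nH]1`: > 100000 nM, a limit of the assay
compound 3 `Nc1nc2c(c(-c3ccoc3)cn2[C@@H]2O[C@H](CO)[C@@H](O)[C@H]2O)c(=O)[nH]1`: 21500 nM

Of the two true numbers, compound 1 gives 96900 nM and compound 3 gives the lower, 21500 nM. Compound 4 `Nc1nc2c(c(-c3ccsc3)cn2[C@@H]2O[C@H](CO)[C@@H](O)[C@H]2O)c(=O)[nH]1` carries thiophen-3-yl in place of furan-3-yl on an aromatic carbon. Within the data shown here, the only measured step, an at least 4.6-fold lower number from compound 2 to compound 3 (0.66 log units; beyond the scatter), replaces furan-2-yl with furan-3-yl and starts from a limit. It exchanges no furan for a thiophene, so it offers only weak guidance. No step beyond the scatter is therefore expected in this assay. The expected step is a 1.1-fold lower number from compound 3 to compound 4 (0.03 log units; within the scatter). For compound 4 the estimated value is 20000 nM, with an expected range of 5000 nM to 90000 nM.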

Compound 4, half-maximal inhibitory concentration: > 100000 nM
Compound 4: only a limit was reported (the forecaster's own chance of this, stated with the estimate: 15%); at least 5.0-fold (0.69 log units) between middle value and limit.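

In this assay this position separates two rings of equal heavy-atom count, with an at least 4.6-fold higher number from compound 3 to compound 4 (0.66 log units; beyond the scatter). The value of compound 4, > 100000 nM, is a limit of the assay. On the shared core of compound 2, compound 3 and compound 4, only furan-3-yl gives a true number, so exchanging the ring oxygen for sulfur is not a silent change here.

On these data alone, the step from compound 2 to compound 4 cannot be read: the limit of > 100000 nM in this assay, at which 2 of the 4 values shown sit. Still open is whether an aminomethyl group or a phenyl ring on this aromatic carbon would give a true number.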